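Aryloxyacetamide phenoxyacetic acids: lipophilicity, compound 2 to compound 3

A few compounds are considered here, and "the series" means these few. Any claim that something is new, unique, unknown or untested is made for them only; others in the source may bear on it.

Measured compounds:
compound 1, `Cc1ccccc1OCC(=O)Nc1ccc(OCC(=O)O)c(F)c1`: "not determined" (no result reported)
compound 2, `CC(C)c1cccc(OCC(=O)Nc2ccc(OCC(=O)O)c(F)c2)c1`: 0.15

In a physicochemical assay for lipophilicity, using the shake flask method, at pH 7.4 (a higher number here means a more lipophilic compound, a lower number a more polar compound), compound 2 gives 0.15. For compound 1 the entry in this assay reads "not determined" (no result reported), so no number exists for it and nothing can be said of how compound 1 and compound 2 compare. Within the data shown here, compound 2 therefore stands as the only numeric result in the set; it is the sole reference point, and no step between two measured compounds is available to show how large a structural change shifts the read-out here.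

Compound 3 `Cc1ccc(C(C)C)cc1OCC(=O)Nc1ccc(OCC(=O)O)c(F)c1` has not yet been measured. It differs from compound 2 by methyl in place of hydrogen on an aromatic carbon. Among the measured compounds shown here, with no measured step in hand, the expected size of this change in this assay rests on the nature of the change alone, and is thought to be a modest upward shift, somewhat beyond the usual scatter of the measurement. The step from compound 2 to compound 3 is estimated as a number 0.40 log units higher from compound 2 to compound 3 (beyond the scatter). Compound 3 is accordingly expected to give 0.55 in this assay, with a range from 0.2 to 0.9.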

Compound 3, distribution coefficient: 0.47
Estimate against measurement, compound 3: 0.08 log units above; measured number inside the range.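

The series now has its first measured step in this assay, and it is modest in size: a number 0.32 log units higher from compound 2 to compound 3 (beyond the scatter) for methyl in place of hydrogen on an aromatic carbon. This gives the first measured size for a change at this position, ortho to a large group and para to an isopropyl group, and shows that adding this single carbon with no hydrogen-bond donors or acceptors and no net charge moves the read-out beyond the usual scatter, though this holds for this one pair only. No measurement among these compounds bears on why the number moves by this amount.

On these data alone, whether another group at this position, such as ethyl, a longer chain, an amine or a carboxylic acid, would give a step of similar size or direction remains open, as does whether methyl on a different aromatic carbon would match this step. With a single step in hand, no trend can be drawn for the series, and the entry for compound 1 supplies no number to set against it.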